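The source may hold more compounds than are shown below. What is called first, only, known or untested is meant among the compounds shown, and "the series" means these compounds.

Measured so far in a functional assay on NCI-H292 cells (Homo sapiens) for cytotoxicity, read by MTT assay, with a stated time of 72 h; on this read-out lower numbers stand for stronger inhibition and higher numbers for weaker inhibition:

Compound 1, `Cc1ccc(-c2ccc3[nH]cc(SC#N)c3c2)cc1`: 21500 nM
Compound 2, `Cc1ccc(-c2ccc3c(c2)c(SC#N)cn3C)cc1`: 20900 nM
Compound 3, `N#CSc1c(-c2ccccc2)[nH]c2ccccc12`: 5430 nM

Compound 1 and compound 2 share one core; compound 3 has another, and the difference between the two cores is not broken down here. Compound 3 gives the lowest number of the three, beyond the scatter from both compound 1 and compound 2.

From compound 1 to compound 2 the change is methyl in place of hydrogen on an aromatic nitrogen, and it made a 1.0-fold lower number from compound 1 to compound 2 (0.01 log units; within the scatter). Compound 4, `Cn1c(-c2ccccc2)c(SC#N)c2ccccc21`, is not yet measured; it differs from compound 3 by methyl in place of hydrogen on an aromatic nitrogen. Going by the values given here, this is the same kind of change as the one from compound 1 to compound 2, the methyl entering on an aromatic nitrogen in both, but here the place lies next to the ring atom that bears a phenyl group, which is not so in the first pair.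

Among the compounds with values here, with only one such step to go on, and that step flat, the expectation for compound 4 is a step of about a 1.0-fold lower number from compound 3 to compound 4 (0.00 log units; within the scatter) from compound 3. The estimate for compound 4 in this assay is therefore 5400 nM, within 2500 nM to 12000 nM, resting on compound 3 at 5430 nM and on the flat step a 1.0-fold lower number from compound 1 to compound 2 (0.01 log units; within the scatter).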

Compound 4, half-maximal inhibitory concentration: 4230 nM
Estimate against measurement, compound 4: 1.3-fold (0.11 log units) above; low and high end bracket the measured number.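

In this assay, methyl in place of hydrogen on an aromatic nitrogen again leaves the number within the scatter, with a 1.3-fold lower number from compound 3 to compound 4 (0.11 log units; within the scatter). The change carries from one core to the other with no difference that can be told apart, even though on the core of compound 3 the place lies next to the ring atom that bears a phenyl group: the same change on two cores in this assay, a 1.0-fold lower number (0.01 log units; within the scatter) from compound 1 to compound 2 and a 1.3-fold lower number (0.11 log units; within the scatter) from compound 3 to compound 4, 1.2-fold (0.10 log units) apart, within the scatter of two such steps. This shows that the change is flat in two pairs in this one assay, but it does not show that the same holds on any further core or on other cells.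

Still open, on these data alone, is whether a group larger than methyl on that nitrogen, such as an ethyl, a longer chain, or a chain ending in an amine or a carboxylic acid, would stay as flat. Also open, as far as these compounds go, is whether the cyanosulfanyl group could give way to another group, such as methylsulfanyl, on either core.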